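Solubility notes on a fused triazolopyrimidine amine series

The compounds below may be only part of what the source reports. "The series", "measured", "known", "first", "only" and "open" are said of these compounds alone.

Measured so far:
- compound 1 `Fc1ccc2c(c1CNc1ncc(Oc3ccccc3)c3nncn13)CCO2`: 8000 nM
- compound 2 `Cc1ncccc1-c1cnc(NCc2c(F)ccc3c2CCO3)c2ncc(=O)[nH]c12`: 29000 nM
- compound 3 `CN(C)Cc1ccc2c(c1)CN(c1cnc(NCc3c(F)ccc4c3CCO4)n3cnnc13)C2=O`: 12000 nM

In a physicochemical assay for solubility, read by LC-MS, in phosphate buffer, with a stated time of 24 h, at pH 7.4 (a lower number here means a less soluble compound, a higher number a more soluble compound), compound 1 gives the lowest of the three numbers. Compound 3 sits nearest, a gap within the scatter; compound 2 is furthest, a gap beyond the scatter. Compound 4 `O=C1CC2(CC2)CN1c1cnc(NCc2c(F)ccc3c2CCO3)n2cnnc12` is not yet measured. Against compound 1 it carries a group of 8 heavy atoms (6 carbon, 1 nitrogen, 1 oxygen; one three-membered non-aromatic ring of carbon only, one five-membered non-aromatic ring with 1 hetero atom) in place of a group of 7 heavy atoms (6 carbon, 1 oxygen; one six-membered aromatic ring of carbon only), on an aromatic carbon on the aromatic carbon ortho to a fused ring. For the measured compounds named here, no measured pair isolates this change. Given that compound 3, which also bears a five-membered ring with a carbonyl on this side of the core, gives 12000 nM, a small upward step is expected, a 1.9-fold higher number from compound 1 to compound 4 (0.27 log units; within the scatter), possibly still within the scatter. Compound 4 is thus estimated at 15000 nM, between 6000 nM and 40000 nM.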

Compound 4, solubility: 130000 nM
Compound 4: the middle estimate sits 8.7-fold (0.94 log units) below what was measured; measured number outside the range, above it.
By their numbers in this assay, from the lowest: compounds 1 and 3 (each within the scatter of the next); then compound 2; then compound 4.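

In this assay, the aromatic carbon ortho to a fused ring proves highly sensitive to the group it carries: the group with one three-membered and one five-membered non-aromatic ring in place of phenoxy gives a 16-fold higher number from compound 1 to compound 4 (1.21 log units; beyond the scatter). The two groups match in hydrogen-bond donors and acceptors, and neither carries a net charge, so these counts do not separate them. Nothing in hand accounts for the size of this step.

Still open, as far as these compounds go, is what the three-membered ring contributes apart from the five-membered ring. Also open, from the compounds shown here alone, is how a carboxylic acid or a morpholine at this position would read in this assay.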